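Aryl on the Indole Nitrogen of a Sigma-1 Ligand

The source may report more compounds than this note shows. Statements on the series, on what has been measured and on what is new or still open speak of the compounds shown alone.

Compound 1 `c1ccc(C2CCN(CCCCc3c[nH]c4ccccc34)CC2)cc1` holds the lowest of the two numbers measured in an assay on isolated protein for binding affinity to Sigma non-opioid intracellular receptor 1 (Rattus norvegicus); on this read-out higher numbers stand for weaker inhibition and lower numbers for stronger inhibition: in this assay compound 1 gives 1.5 nM. Going by the values given here, the only other measured compound, compound 2 `Fc1ccc(N2CCN(CCCCc3cn(-c4ccc(F)cc4)c4ccccc34)CC2)cc1`, gives 440 nM in this assay, a much higher number that lies far beyond the scatter. Among the compounds with values here, compound 2 differs from compound 1 in more than one place, so no single step between the two is drawn, and their values are simply set side by side.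

Compound 3 `Fc1ccc(-n2cc(CCCCN3CCC(c4ccccc4)CC3)c3ccccc32)cc1` has not been measured. It differs from compound 1 in exactly one place: 4-fluorophenyl in place of hydrogen on an aromatic nitrogen. Within the data shown here, no measured pair isolates this change, so the size of the step has to be estimated. Compound 2, which carries the same 4-fluorophenyl on the aromatic nitrogen but also differs elsewhere, gives 440 nM, and this points toward a weaker compound 3. The expected step from compound 1 to compound 3 is a 20-fold higher number from compound 1 to compound 3 (1.30 log units; beyond the scatter), a rise beyond the scatter. Compound 3 is therefore estimated at 30 nM, within a range from 5 nM to 300 nM.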

Compound 3, half-maximal inhibitory concentration: 44 nM
Estimate against measurement, compound 3: 1.5-fold (0.17 log units) below; low and high end bracket the measured number.
By their numbers in this assay, from the lowest: compound 1; then compound 3; then compound 2.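

Read alone for the first time, 4-fluorophenyl in place of hydrogen on the aromatic nitrogen gives a 29-fold higher number from compound 1 to compound 3 (1.47 log units; beyond the scatter) in this assay, a large step well beyond the scatter. This position is therefore not indifferent to the change, and compound 3 gives 44 nM with the rest of the core of compound 1 left untouched. No measurement shown here accounts for the size of this step, so the data record the rise without explaining it.

The compounds shown leave open how much of the step belongs to the ring that enters and how much to the fluorine it carries, which a plain phenyl on the same nitrogen would separate. They also leave open whether any group on this nitrogen raises the number to a similar extent, as a methyl, a benzyl or an acetyl group there would show, and whether the step keeps its size on a compound with a shorter or longer chain.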